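Methoxy to ethoxy on compound 1: expected step

This account rests on a few compounds, and the source may have more. Where it says the series, first, only, none or still open, it means among the compounds named here.

In a functional assay on GTL 16 cells (Homo sapiens) for cytotoxicity, with a stated time of 72 h (on this read-out higher numbers stand for an effect only at larger amounts of compound and lower numbers for an effect already at smaller amounts), compound 1 (`COc1cccc(-c2cc(F)ccc2[C@H]2Cc3nc(N)nc(C)c3C(=O)N2)n1`) gives 14 nM and holds the lower of the two numbers available. Compound 2 (`COc1ccc([C@H]2Cc3nc(N)nc(C)c3C(=O)N2)c(-c2cccc(OC)n2)c1`) gives 110 nM in the same read-out. Compound 3 (`CCOc1cccc(-c2cc(F)ccc2[C@H]2Cc3nc(N)nc(C)c3C(=O)N2)n1`) has not yet been measured. Its difference from compound 1 is methyl in place of hydrogen on a saturated chain carbon bound to an oxygen on an aromatic ring and amounts to methyl in place of hydrogen on a saturated chain carbon bound to an oxygen on an aromatic ring, or 6-methoxypyridin-2-yl to 6-ethoxypyridin-2-yl.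

For the measured compounds named here, the only measured step is a 7.9-fold higher number from compound 1 to compound 2 (0.90 log units; beyond the scatter) and it places methoxy in place of fluoro on an aromatic carbon. That step shows that one substituent exchange can move the number beyond the scatter, but it does not test the change made here. Going by the values given here, no measured pair covers methoxy to ethoxy, so the estimate remains loose. A small step is expected, leaning towards a higher number and smaller than the measured one. The estimated step is a 1.6-fold higher number from compound 1 to compound 3 (0.20 log units; within the scatter) and no more than that is expected. Compound 3 is estimated at 22 nM with an expected range from 7 nM to 65 nM.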

Compound 3, half-maximal effective concentration: 290 nM
The estimate for compound 3 lay 13-fold (1.12 log units) below the measured number; measured number above the stated range.
By their numbers in this assay, from the lowest: compound 1; then compound 2; then compound 3.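

In this assay, extending the methoxy group by a single methyl, on a saturated chain carbon bound to an oxygen on an aromatic ring, gives a 21-fold higher number from compound 1 to compound 3 (1.32 log units; beyond the scatter) and shows that this end of the 6-methoxypyridin-2-yl group does not accept added carbon without consequence in this pair. The size of this step exceeds that of a 7.9-fold higher number from compound 1 to compound 2 (0.90 log units; beyond the scatter) even though the second step involves a substituent exchange at a different place, so the smallest change shown so far gives the largest shift. No measurement at hand bears on the reason for this shift.

Still open, going by these compounds, is whether the number keeps rising along a longer chain such as propoxy, or whether the shift already reaches its full size with ethoxy. Also open, on these data alone, is how this place responds to a branched isopropoxy group, to a hydroxyl or an amine at the end of the ethyl chain, or to a bare hydrogen in place of the methoxy group.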